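The source may hold more compounds than are shown below. What is called first, only, known or untested is meant among the compounds shown, and "the series" means these compounds.

In a functional assay on A549 cells (Homo sapiens) for inhibition, read by sulforhodamine B assay, with a stated time of 72 h (a higher number here means a weaker inhibitor, a lower number a stronger inhibitor), three amides built on the same core have been measured. Compound 1 `Nc1sc(-c2ccc(Cl)cc2)c(-c2ccc(Cl)cc2)c1C(=O)N1CCCCC1=O` gives 1820 nM, compound 2 `Nc1sc(-c2ccc(Cl)cc2)c(-c2ccc(Cl)cc2)c1C(=O)NC1CCC1` gives 12500 nM, and compound 3 `Nc1sc(-c2ccc(Cl)cc2)c(-c2ccc(Cl)cc2)c1C(=O)N1CCOCC1` gives 1870 nM. Compound 3 therefore stands level with compound 1, and the step of a 6.7-fold lower number from compound 2 to compound 3 (0.83 log units; beyond the scatter) sets it clearly apart from compound 2.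

Compound 4 `Nc1sc(-c2ccc(Cl)cc2)c(-c2ccc(Cl)cc2)c1C(=O)N1CCC(=O)CC1=O` carries 2,4-dioxopiperidin-1-yl in place of morpholin-4-yl on a carbonyl carbon. The closest evidence is the step of a 1.0-fold higher number from compound 1 to compound 3 (0.01 log units; within the scatter), which lies within the scatter, since the 2-oxopiperidin-1-yl of compound 1 has a name close to the entering group. The larger steps, a 6.9-fold higher number from compound 1 to compound 2 (0.84 log units; beyond the scatter) and a 6.7-fold lower number from compound 2 to compound 3 (0.83 log units; beyond the scatter), both involve cyclobutylamino, which compound 4 does not carry. They warn that this position can matter, but they say little about this particular change.

No step beyond the scatter is therefore expected in this assay, and the expected step is a 1.0-fold higher number from compound 3 to compound 4 (0.01 log units; within the scatter). For compound 4 the estimated value is 1900 nM, with an expected range of 650 nM to 6000 nM.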

Compound 4, half-maximal inhibitory concentration: 4090 nM
Compound 4: the middle estimate sits 2.2-fold (0.33 log units) below what was measured; the range from low to high includes it.
By their numbers in this assay, from the lowest: compounds 1 and 3 (each within the scatter of the next); then compound 4; then compound 2.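

At this place on the carbonyl carbon, the six-membered rings that had looked interchangeable now separate, with a 2.2-fold higher number from compound 3 to compound 4 (0.34 log units; beyond the scatter) and a 2.2-fold higher number from compound 1 to compound 4 (0.35 log units; beyond the scatter) in this assay, so which six-membered ring is attached can shift the number. The 2,4-dioxopiperidin-1-yl group still stays clear of cyclobutylamino, with a 3.1-fold lower number from compound 2 to compound 4 (0.49 log units; beyond the scatter), which places it in an intermediate position among the groups shown. No measurement given here accounts for these differences.

On these data alone, it remains open whether the rise in the number belongs to the ring carbonyl at position 4 of the piperidine or to some other difference between these rings. As far as these compounds go, it is also open whether an open-chain diethylamino group or a piperazin-1-yl ring, with its second ring nitrogen, would fall nearer compound 1 and compound 3 or nearer compound 2.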